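Removing a Sulfated Side Chain from a Disaccharide Binder

The source may hold more compounds than are shown below. What is called first, only, known or untested is meant among the compounds shown, and "the series" means these compounds.

Compound 1 `CO[C@@H]1O[C@H](COS(=O)(=O)O)[C@@H](O[C@H]2O[C@H](CO)[C@H](O)[C@H](O)[C@H]2OS(=O)(=O)O)[C@H](OS(=O)(=O)O)[C@H]1OS(=O)(=O)O`: 77500 nM
Compound 2 `CO[C@@H]1O[C@H](COS(=O)(=O)O)[C@@H](O[C@H]2O[C@H](COS(=O)(=O)O)[C@H](O)[C@H](O)[C@H]2OS(=O)(=O)O)[C@H](OS(=O)(=O)O)[C@H]1OS(=O)(=O)O`: 21800 nM

Both compounds were tested in an assay on isolated protein for binding affinity to fibroblast growth factor 1 (Homo sapiens); a lower number here means tighter binding, a higher number weaker binding. Going by the values given here, of the two numbers measured, compound 1 gives the higher one, so it is the weaker binder of the pair; its only neighbour is compound 2, reached by the step of a 3.6-fold lower number from compound 1 to compound 2 (0.55 log units; beyond the scatter), in which one extra sulfo group was added. Compound 3 `CO[C@@H]1OC[C@@H](O[C@H]2O[C@H](CO)[C@H](O)[C@H](O)[C@H]2OS(=O)(=O)O)[C@H](OS(=O)(=O)O)[C@H]1OS(=O)(=O)O` is derived from compound 1 by a single change: hydrogen in place of (sulfooxy)methyl on a saturated ring carbon. Among the compounds with values here, no measured pair removes a group of this kind, so the only guide is the step of a 3.6-fold lower number from compound 1 to compound 2 (0.55 log units; beyond the scatter) read in reverse: adding a sulfo group tightened binding modestly, and taking a whole sulfated group away is expected to loosen it by a comparable or somewhat larger amount. Compound 3 is therefore expected to give 200000 nM, with a range from 70000 nM to 600000 nM, an expected step of a 2.6-fold higher number from compound 1 to compound 3 (0.41 log units; beyond the scatter).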

Compound 3, dissociation constant: 1400000 nM
Estimate against measurement, compound 3: 7.0-fold (0.85 log units) below; measured number above the stated range.
By their numbers in this assay, from the lowest: compound 2; then compound 1; then compound 3.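

In this assay, going by these compounds alone, the (sulfooxy)methyl on this saturated ring carbon, next to the ring oxygen, proves to matter far more than the earlier compounds suggested: replacing it with hydrogen gives an 18-fold higher number from compound 1 to compound 3 (1.26 log units; beyond the scatter) and turns compound 1 into a much weaker binder. This large step outweighs a 3.6-fold lower number from compound 1 to compound 2 (0.55 log units; beyond the scatter) where a single sulfo group was added elsewhere in the molecule, so the two changes cannot be treated as similar in size. Nothing available explains why removing this group costs so much.

On these data alone, the change removes the sulfo group and the carbon that carries it together, so their separate contributions remain unknown. A hydroxymethyl at this place would separate the two, while a carboxylic acid there would show whether another group can take the place of the (sulfooxy)methyl.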